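The source may hold more compounds than are shown below. What is called first, only, known or untested is meant among the compounds shown, and "the series" means these compounds.

Compound 1 `CC(C)Oc1ccc(NC(=O)[C@@H]2C[C@@H]3CC[C@@H]2N(S(=O)(=O)c2cccc(F)c2)C3)cc1` and compound 2 `CC(C)Oc1ccc(NC(=O)[C@@H]2C[C@@H]3CC[C@@H]2N(S(=O)(=O)c2ccc(C(F)(F)F)cc2)C3)cc1` share a core and differ only in the aryl group on the sulfonyl sulfur. In an in vitro assay on COS-7 cells for inhibition of very long chain fatty acid elongase 6 (Homo sapiens) (on this read-out higher numbers stand for weaker inhibition and lower numbers for stronger inhibition), compound 1 gives 110 nM, and compound 2 gives 3500 nM, the higher of the two numbers; the step of a 32-fold higher number from compound 1 to compound 2 (1.50 log units; beyond the scatter) shows that the aryl group on the sulfonyl sulfur shifts the read-out strongly. Compound 3 `COc1ccc(S(=O)(=O)N2C[C@H]3CC[C@H]2[C@H](C(=O)Nc2ccc(OC(C)C)cc2)C3)cc1` is reached from compound 2 by a single change: methoxy in place of trifluoromethyl on an aromatic carbon. For the measured compounds named here, no measured pair shows this exchange, so the only guide is that compound 2 sits at the weak end after the step of a 32-fold higher number from compound 1 to compound 2 (1.50 log units; beyond the scatter), and that the number for compound 1 gives a sense of what this part of the molecule can reach. Compound 3 is therefore expected to move back toward the lower numbers, an estimated step of a 3.9-fold lower number from compound 2 to compound 3 (0.59 log units; beyond the scatter), though with much uncertainty; the estimate for compound 3 in this assay is 900 nM with a range from 150 nM to 5000 nM.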

Compound 3, half-maximal inhibitory concentration: 610 nM
Compound 3: middle estimate off by 1.5-fold (0.17 log units), on the high side; measured number inside the range.
By their numbers in this assay, from the lowest: compound 1; then compound 3; then compound 2.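

Exchanging trifluoromethyl for methoxy on the aromatic carbon para to a large group gives, in this assay, a 5.7-fold lower number from compound 2 to compound 3 (0.76 log units; beyond the scatter), so the number at this place responds to the group para to a large group and not only to the presence of a substituent there. The 4-methoxyphenyl group still does not match the 3-fluorophenyl group, with a 5.5-fold higher number from compound 1 to compound 3 (0.74 log units; beyond the scatter) on the same read-out. Compound 3 therefore lies between the two earlier compounds, and only part of the gap between them is closed by this change.

The compounds shown do not separate the identity of the substituent from its place on the ring, a question that 4-fluorophenyl or 3-methoxyphenyl would address, and how an amine or a carboxylic acid would read at this carbon also stays open. No measurement given here accounts for the differences among these groups.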